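A Second Methyl Group Added to Compound 2

The compounds below may be only part of what the source reports. "The series", "measured", "known", "first", "only" and "open" are said of these compounds alone.

Three compounds have been measured in a toxicity assay on the whole organism with Rattus norvegicus as the target, at a dose of 200 mg/kg by the oral route (on this read-out lower numbers stand for a weaker effect and higher numbers for a stronger effect at the one dose given), and their values are these:

compound 1, `Clc1ccc(OCC2=NCCO2)cc1`, gives 20%
compound 2, `Cc1ccccc1OCC1=NCCO1`, gives 20%
compound 3, `Cc1cc(OCC2=NCCO2)ccc1Cl`, gives 30%

Compound 1 and compound 3 differ in one place, by methyl in place of hydrogen on an aromatic carbon. This change made a step of a number 10 percentage points higher from compound 1 to compound 3 (within the scatter) in this assay. Compound 2 rests on a different core from compound 1; the difference between the two cores is not broken down here. At the digits given, compound 2 stands level with compound 1, and together they hold the lowest two of the three numbers, while compound 3 gives 30%.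

The unmeasured compound 4, `Cc1ccc(OCC2=NCCO2)c(C)c1`, differs from compound 2 by methyl in place of hydrogen on an aromatic carbon. It is the same kind of change as that from compound 1 to compound 3, but not the same: in compound 3 the entering methyl sits ortho to a chloro group and meta to a group of 7 heavy atoms, whereas in compound 4 it sits meta to a methyl group and para to a group of 7 heavy atoms. Among the compounds with values here, with only one earlier example of this kind, the expectation for compound 4 rests on compound 1 and compound 3, whose step a number 10 percentage points higher from compound 1 to compound 3 (within the scatter) stayed within the scatter. A step of a number 5 percentage points higher from compound 2 to compound 4 (within the scatter) is therefore expected from compound 2 to compound 4. Compound 4 is estimated to give 25% in this assay, most likely between 10% and 40%.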

Compound 4, a percentage reported as activity, at one dose (the size of the read-out at that dose, not a potency): 25%
Beside the measured number, compound 4's estimate shows no gap at the digits printed; the measured number falls inside the stated range.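

In this assay, methyl in place of hydrogen on an aromatic carbon of compound 2 gave a step of a number 5 percentage points higher from compound 2 to compound 4 (within the scatter). Set beside the earlier step, the same change reads alike on the two cores: the same change on two cores in this assay, a number 10 percentage points higher (within the scatter) from compound 1 to compound 3 and a number 5 percentage points higher (within the scatter) from compound 2 to compound 4, 5 percentage points apart, within the scatter of two such steps. This shows that, in these two pairs, the change carried from one core to the other without a difference that stands out from the scatter, but neither step stands out from the scatter on its own, so it does not show that the methyl has a reliable effect on either core, and two pairs, with the methyl in compound 4 sitting meta to a methyl group and para to a group of 7 heavy atoms and elsewhere in compound 3, cannot establish a rule for the series.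

The compounds shown carry only methyl and chloro on the aromatic ring, and it stays open whether a methoxy group, an amine or a carboxylic acid there would give a step beyond the scatter in this assay. From the compounds shown here alone, it also stays open whether a longer chain in place of the group of 7 heavy atoms would leave the methyl step as small as it is here.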